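This account rests on a few compounds, and the source may have more. Where it says the series, first, only, none or still open, it means among the compounds named here.

Working notes on the series. Three compounds of the shared core have been run in an ADME assay on Vero cells (Chlorocebus sabaeus) for cytotoxicity, read by neutral red uptake, tested at 1575 ug/mL; a higher number here means a weaker effect of the compound at the concentration tested, a lower number a stronger effect: compound 1 `O=C1CSC(c2c(Cl)cccc2Cl)N1CCN1CCCCC1`, compound 2 `O=C1CSC(c2cccc(Cl)c2)N1CCN1CCCCC1` and compound 3 `O=C1CSC(c2ccc(F)cc2)N1CCN1CCCCC1`. In this assay compound 1 gives 10%, compound 2 gives 20% and compound 3 gives 14%. Compound 3 thus sits in the middle of the three numbers, but its nearest neighbour, compound 1, and its furthest, compound 2, both lie within the scatter of it, so the three measured compounds cannot be told apart on these data.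

The next compound, compound 4 `O=C1CSC(c2ccccc2Cl)N1CCN1CCCCC1`, is not yet measured. It differs from compound 3 only in the aryl group on the saturated ring carbon: 2-chlorophenyl in place of 4-fluorophenyl on a saturated ring carbon. Going by the values given here, the one measured step that bears on such a swap of the aryl group is a number 6 percentage points lower from compound 2 to compound 3 (within the scatter), which did not move the read-out beyond the scatter. Compound 1, which also carries chlorine on its aryl group, gives a number in the same band as the rest. On this basis no step beyond the scatter is expected for compound 4 in this assay; the expected step is no change at the digits printed from compound 3 to compound 4 (within the scatter). The value estimated for compound 4 is 14%, with a range from 5% to 25%.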

Compound 4, a percentage reported as activity, at one concentration (the size of the read-out at that concentration, not a potency): 16%
For compound 4 the middle estimate is 2 percentage points below the measured one; the range from low to high includes it.
By their numbers in this assay, from the lowest: compounds 1, 3, 4 and 2 (each within the scatter of the next).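

In this assay the swap to 2-chlorophenyl on the saturated ring carbon gives a number 2 percentage points higher from compound 3 to compound 4 (within the scatter), so a different halogen at a different place on this aryl group does not separate the two compounds. The series now also holds a comparison of where a single chlorine stands, with a number 4 percentage points lower from compound 2 to compound 4 (within the scatter), and one of the number of chlorines on the aryl group, with a number 6 percentage points higher from compound 1 to compound 4 (within the scatter), and neither of these separates its pair. All four compounds therefore remain indistinguishable at this position for the halogen patterns shown, and no measurement on hand offers an explanation for this flat result.

Every aryl group shown carries only chlorine or fluorine, so it remains open whether a phenyl bearing a carboxylic acid, an amine or a methoxy group would give a read-out outside this band. The compounds shown also all keep the same group of 8 heavy atoms on the ring nitrogen, so they say nothing about how a shorter chain or an open-chain amine there would read in this assay.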